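Inverting one ring stereocentre in a naphthyl methylene lactone

The source may report more compounds than this note shows. Statements on the series, on what has been measured and on what is new or still open speak of the compounds shown alone.

Measured compounds:
compound 1, `C=C1C(=O)O[C@H](c2ccc3ccccc3c2)[C@H]1C`: in a functional assay on PANC-1 cells (Homo sapiens) for cytotoxicity, read by MTT assay, with a stated time of 72 h, tested at 10 uM (on this read-out higher numbers stand for a weaker effect at the one concentration tested and lower numbers for a stronger effect), compound 1 gives 22%
compound 2, `C=C1C(=O)O[C@@H](c2ccc3ccccc3c2)[C@H]1c1ccccc1`: in this assay compound 2 gives 33%

Of the two numbers, compound 2 gives the highest, and its nearest neighbour is compound 1, whose number is lower by a gap beyond the scatter. Compound 2 therefore shows the weaker effect of the pair in this assay at the one concentration tested.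

Compound 3, `C=C1C(=O)O[C@H](c2ccc3ccccc3c2)[C@H]1c1ccccc1`, has not yet been measured. Compared with compound 2, (the two compounds have the same atoms and bonds and differ only in configuration as drawn: 1 of 2 stereo elements differ; a stereocentre at a saturated ring carbon is drawn R in compound 2 and S in compound 3). The two compounds are thus diastereomers that share every atom and bond.

Among the measured compounds shown here, no step between measured compounds is available to calibrate what such an inversion does in this assay, so the size and direction of the change cannot be read from the data. The expectation is that compound 3 lands near compound 2, with the step of a number 1 percentage points lower from compound 2 to compound 3 (within the scatter) expected to fall within the scatter, although a larger move in either direction cannot be excluded.

For compound 3 the estimated value in this assay is 32%, with a range from 12% to 60%.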

Compound 3, a percentage reported as activity, at one concentration (the size of the read-out at that concentration, not a potency): 13%
Compound 3: middle estimate off by 19 percentage points, on the high side; the measured number falls inside the stated range.
By their numbers in this assay, from the lowest: compounds 3 and 1 (each within the scatter of the next); then compound 2.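

In this assay, configuration at a saturated ring carbon matters on its own account: inverting that single stereocentre gives a number 20 percentage points lower from compound 2 to compound 3 (beyond the scatter) and leaves compound 3, drawn S there, with the stronger effect of the diastereomeric pair. That step can be laid to the stereocentre alone, and the ground for this is: the fact that compounds 2 and 3 differ only in the configuration as drawn. Phenyl in place of methyl on a saturated ring carbon, by contrast, gives a number 9 percentage points lower from compound 1 to compound 3 (within the scatter) and so does not separate the two compounds in this read-out, which means that the phenyl group as such shows no effect of its own in this comparison.

The compounds shown leave open whether the same inversion would bring a step of similar size with methyl in place of phenyl, and what inverting the other stereocentre would do. They also leave open how a longer chain, an amine or a carboxylic acid on that ring carbon would read out, and whether the difference between the diastereomers holds at concentrations other than the single one tested.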